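Cyclopropane amides on colon cancer cells: anilide versus benzylamide

The source may report more compounds than this note shows. Statements on the series, on what has been measured and on what is new or still open speak of the compounds shown alone.

Compound 1 `CCOC(=O)[C@]1(C(=O)Nc2ccccc2)C[C@H]1c1cc(OC)c(OC)c(OC)c1` in a functional assay on SW480 cells (Homo sapiens) for cytotoxicity, read by MTT assay, with a stated time of 48 h (a higher number here means a weaker inhibitor, a lower number a stronger inhibitor), gives > 100000 nM, which is a limit of the assay rather than a number.
Compound 2 `CCOC(=O)[C@]1(C(=O)NCc2ccc(C)cc2)C[C@H]1c1cc(OC)c(OC)c(OC)c1` in this assay gives 36400 nM.
Compound 3 `COc1cc([C@H]2C[C@]2(CO)C(=O)NCc2ccc(C)cc2)cc(OC)c1OC` in this assay gives 94000 nM.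

One measured step exists: phenyl in place of 4-methylbenzyl on an amide-type nitrogen. It brings an at least 2.7-fold higher number from compound 2 to compound 1 (0.43 log units; beyond the scatter), and the end point is only a limit (the limit of > 100000 nM in this assay, at which 1 of the 3 values shown sits), so the true size of the step is not known. The cores of compound 2 and compound 3 differ in a way that is not broken down here; compound 3 stands at a higher number than compound 2 in this assay.

Compound 4 `COc1cc([C@H]2C[C@]2(CO)C(=O)Nc2ccccc2)cc(OC)c1OC` carries the same change on the core of compound 3: phenyl in place of 4-methylbenzyl on an amide-type nitrogen. The place is the same in both pairs. Starting from compound 3, a step of similar size to the measured one is expected, a 2.7-fold higher number from compound 3 to compound 4 (0.42 log units; beyond the scatter), resting on an at least 2.7-fold higher number from compound 2 to compound 1 (0.43 log units; beyond the scatter). Compound 4 is therefore estimated at 250000 nM in this assay, most likely reported only as a limit.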

Compound 4, half-maximal inhibitory concentration: > 100000 nM
Compound 4: a limit, no number (the forecaster's own chance of this, stated with the estimate: 80%); the middle value lies beyond the limit too.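

Compound 4 gives > 100000 nM in this assay, which is a limit of the assay and not a number. On the core of compound 3, phenyl in place of 4-methylbenzyl on the amide-type nitrogen brings an at least 1.0-fold higher number from compound 3 to compound 4 (0.02 log units; that floor lies within the scatter), so this pair alone does not establish a change beyond the scatter. Both anilides therefore fit the direction seen on the first core, but neither the size of the step nor its equality across the two cores is shown: the same change on two cores in this assay, an at least 2.7-fold higher number (0.43 log units; beyond the scatter) from compound 2 to compound 1 and an at least 1.0-fold higher number (0.02 log units; that floor lies within the scatter) from compound 3 to compound 4; the limit leaves it open whether they differ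

Going by these compounds, the true anilide values remain open, as does the relation between the two steps. Also open, on these data alone, is how an unsubstituted benzyl or a longer phenethyl chain on the amide-type nitrogen, or a carboxylic acid on the core, would read in this assay.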